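The source may hold more compounds than are shown below. What is called first, only, known or untested is meant among the compounds shown, and "the series" means these compounds.

Of the compounds shown here, two on one shared core have been tested so far in a functional assay on MDA-MB-231 cells (Homo sapiens) for inhibition, read by MTT assay, with a stated time of 48 h (on this read-out higher numbers stand for weaker inhibition and lower numbers for stronger inhibition), and only one of them gives a true number. Compound 1 `COc1cc(-c2cc(-c3ccc(Cl)cc3)nc(-c3ccccc3)n2)cc(OC)c1OC` reads > 25000 nM in this assay and this is a limit of the assay, not a number. For the measured compounds named here, compound 2 `COc1cc(-c2cc(-c3ccccc3)nc(-c3ccccc3)n2)cc(OC)c1OC` gives 5870 nM as the only number available, so its standing rests on that single comparison. Compound 3 `COc1ccc(-c2cc(-c3cc(OC)c(OC)c(OC)c3)nc(-c3ccccc3)n2)cc1` differs from compound 2 by methoxy in place of hydrogen on an aromatic carbon and thus carries methoxy in place of hydrogen on an aromatic carbon, para to a large group, a change of phenyl to 4-methoxyphenyl. Going by the values given here, one measured step bears on this. From the compounds shown here alone, that step, an at least 4.2-fold lower number from compound 1 to compound 2 (0.62 log units; beyond the scatter), has hydrogen in place of chloro on the same ring, and its true size stays open given the limit of > 25000 nM in this assay, at which 1 of the 2 values shown sits, for compound 1. Chloro is not methoxy, so it is only a loose guide. A modest move towards a higher number, meaning weaker inhibition, is therefore expected in this assay for the new group. The estimated change is a 1.7-fold higher number from compound 2 to compound 3 (0.23 log units; within the scatter) and it could still prove small. For compound 3 the estimated value is 10000 nM with an expected range from 3500 nM to 28000 nM.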

Compound 3, half-maximal inhibitory concentration: 3390 nM
For compound 3 the middle estimate is 2.9-fold (0.47 log units) above the measured one; measured number below the stated range.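

In this assay the change of phenyl to 4-methoxyphenyl gives a 1.7-fold lower number from compound 2 to compound 3 (0.24 log units; within the scatter), so compound 2 and compound 3 cannot be told apart here, and the move towards weaker inhibition that the chloro step had suggested does not appear for methoxy. The position, para to a large group, therefore does not treat every substituent alike, since exchanging chloro for methoxy at this same place gives an at least 7.3-fold lower number from compound 1 to compound 3 (0.86 log units; beyond the scatter). Compound 1 reads > 25000 nM, which is a limit of the assay and not a number, and the true size of both steps that start from it stays open: the limit of > 25000 nM in this assay, at which 1 of the 3 values shown sits.

With only hydrogen, chloro and methoxy shown at this place, it remains open whether an amine, a hydroxyl or a carboxylic acid would read with compound 2 and compound 3 or would lose inhibition as chloro does in compound 1. From the compounds shown here alone, it is also open whether a longer chain such as ethoxy would be accepted here, and whether methoxy would read the same elsewhere on the shared core.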